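Replacing trifluoromethyl with pyridin-2-yl on an oxazole ketone

This account rests on a few compounds, and the source may have more. Where it says the series, first, only, none or still open, it means among the compounds named here.

Compound 2 `O=C(CCCCCCc1ccccc1)c1nc(C(F)(F)F)co1` gives 214 nM in an assay on HEK-293T cells for inhibition of diacylglycerol lipase-alpha (Homo sapiens), read by colorimetric assay (on this read-out lower numbers stand for stronger inhibition and higher numbers for weaker inhibition), the lowest of the two numbers recorded; compound 1 `O=C(CCCCCc1ccccc1)c1nc2ncccc2[nH]1` gives 1230 nM in this assay, a gap beyond the usual scatter. Compound 3 `O=C(CCCCCCc1ccccc1)c1nc(-c2ccccn2)co1` has not been measured. It differs from compound 2 by pyridin-2-yl in place of trifluoromethyl on an aromatic carbon. Going by the values given here, no measured pair shows this change, so its size and direction are open; compound 3 is expected to show a step of a 2.1-fold lower number from compound 2 to compound 3 (0.33 log units; beyond the scatter) in this assay, a modest shift rather than none. Compound 3 is estimated at 100 nM, within a range of 25 nM to 400 nM.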

Compound 3, half-maximal inhibitory concentration: > 10000 nM
Compound 3: a limit, no number (the forecaster's own chance of this, stated with the estimate: 2%); at least 100-fold (2.00 log units) between middle value and limit.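

Going by these compounds alone, at this aromatic carbon, next to the ring nitrogen, the substituent matters greatly in this assay: pyridin-2-yl in place of trifluoromethyl gives an at least 46-fold higher number from compound 2 to compound 3 (1.66 log units; beyond the scatter) with a large loss of inhibition, which the earlier compounds could not show. The value of compound 3 is a limit of the assay and not a number, so this step has a floor but no measured size: the limit of > 10000 nM in this assay, at which 1 of the 3 values shown sits. From the compounds shown here alone, whether phenyl, which lacks the pyridine nitrogen, or a small methyl group would retain inhibition at this carbon remains open.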